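A Fluorine Swap on the Saturated Ring Carbon

The source may hold more compounds than are shown below. What is called first, only, known or untested is meant among the compounds shown, and "the series" means these compounds.

Measured so far:
- compound 1 `COC(=O)C1=C(C)N=C(C)/C(=C(\O)OC)C1c1cccc(N(C)C)c1` gives 891 nM
- compound 2 `C=Cc1ccccc1C1C(C(=O)OC)=C(C)N=C(C)/C1=C(\O)OC` gives 4.47 nM

These two compounds were tested in a functional assay (muscle tissue) with Cavia porcellus as the target; a lower number here means that less compound is needed, a higher number that more compound is needed for the effect. Compound 2 stands lowest of the two numbers, and the nearest value, that of compound 1, lies far above it, well beyond the scatter of the assay.

Compound 3 `COC(=O)C1=C(C)N=C(C)/C(=C(\O)OC)C1c1cccc(F)c1` is the next step from compound 2. The change is 3-fluorophenyl in place of 2-vinylphenyl on a saturated ring carbon.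

For the measured compounds named here, no pair of measured compounds differs in only one place, so the size of this step is not known from data. The gap between compound 2 and compound 1 shows that the group on this saturated ring carbon can move the number strongly. Compound 3 is expected to need more compound than compound 2, a step of a 22-fold higher number from compound 2 to compound 3 (1.35 log units; beyond the scatter), because compound 1 with a different group at that carbon gives 891 nM. For compound 3 the expected value is 100 nM, within a range from 20 nM to 800 nM.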

Compound 3, half-maximal effective concentration: 20.9 nM
Beside the measured number, compound 3's estimate is 4.8-fold (0.68 log units) above it; measured number inside the range.
By their numbers in this assay, from the lowest: compound 2; then compound 3; then compound 1.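

In this assay, two single changes can now be sized. Replacing 2-vinylphenyl with 3-fluorophenyl on the saturated ring carbon gives a 4.7-fold higher number from compound 2 to compound 3 (0.67 log units; beyond the scatter), a modest step, while fluoro in place of dimethylamino on an aromatic carbon gives a 43-fold lower number from compound 1 to compound 3 (1.63 log units; beyond the scatter), a large one, so among these three compounds the group on that aromatic carbon can move the number far more than the swap between these two aryl groups does. Nothing shown explains the size of either step.

Still open, going by these compounds, is whether the fluoro group or its location on the phenyl ring accounts for the step from 2-vinylphenyl, which differs from 3-fluorophenyl in both respects. On these data alone, how a chloro or methoxy group on the same aromatic carbon would compare with fluoro and dimethylamino also remains unknown.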